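Returning to the Carbocyclic Ring with a Methyl Added

This account rests on a few compounds, and the source may have more. Where it says the series, first, only, none or still open, it means among the compounds named here.

Three compounds share one core and differ only in the bicyclic group on the double-bonded chain carbon bound to an aromatic carbon and a double-bonded chain carbon. Compound 1 `CC/C(=C(/c1ccc(/C=C/C(=O)O)cc1)c1ccc2[nH]ncc2c1)c1ccccc1` carries an indazole and in a functional assay on MCF7 cells (Homo sapiens) for cytotoxicity, read by CellTiter-Glo, with a stated time of 5 days (on this read-out lower numbers stand for stronger inhibition and higher numbers for weaker inhibition), compound 1 gives 7.2 nM. Compound 2 `CC/C(=C(/c1ccc(/C=C/C(=O)O)cc1)c1cc2cn[nH]c2cn1)c1ccccc1` and compound 3 `CC/C(=C(/c1ccc(/C=C/C(=O)O)cc1)c1cnc2[nH]ncc2c1)c1ccccc1` each carry a bicycle with an extra ring nitrogen; in this assay compound 2 gives 442 nM and compound 3 gives 302 nM. Compound 3 therefore stands second highest of the three; one step to it lies within the scatter (a 1.5-fold lower number from compound 2 to compound 3 (0.17 log units; within the scatter)) and the other is large (a 42-fold higher number from compound 1 to compound 3 (1.62 log units; beyond the scatter)).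

Compound 4 `CC/C(=C(/c1ccc(/C=C/C(=O)O)cc1)c1ccc2[nH]ncc2c1C)c1ccccc1` differs from compound 3 in that (a group of 10 heavy atoms (8 carbon, 2 nitrogen; one five-membered aromatic ring with 2 hetero atoms, one six-membered aromatic ring of carbon only) in place of a group of 9 heavy atoms (6 carbon, 3 nitrogen; one five-membered aromatic ring with 2 hetero atoms, one six-membered aromatic ring with 1 hetero atom), on a double-bonded chain carbon bound to an aromatic carbon and a double-bonded chain carbon). This change removes the ring nitrogen and adds a methyl. Among the measured compounds shown here, the step of a 42-fold higher number from compound 1 to compound 3 (1.62 log units; beyond the scatter) bears on it directly and was large; no measured step shows the effect of the methyl. A large drop in this assay is expected, close to reversing that step, so a 30-fold lower number from compound 3 to compound 4 (1.48 log units; beyond the scatter) is estimated. Compound 4 is expected to give 10 nM, ranging from 3 nM to 40 nM.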

Compound 4, half-maximal inhibitory concentration: 50 nM
Beside the measured number, compound 4's estimate is 5.0-fold (0.70 log units) below it; measured number outside the range, above it.
By their numbers in this assay, from the lowest: compound 1; then compound 4; then compounds 3 and 2 (each within the scatter of the next).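

The methyl can now be read on its own: in this assay, methyl in place of hydrogen on an aromatic carbon gives a modest rise in the number (a 6.9-fold higher number from compound 1 to compound 4 (0.84 log units; beyond the scatter)). Even with that methyl, 4-methyl-1H-indazol-5-yl, with a six-membered aromatic ring of carbon only, gives a lower number than either bicycle with the extra ring nitrogen (a 6.0-fold lower number from compound 3 to compound 4 (0.78 log units; beyond the scatter); an 8.8-fold lower number from compound 2 to compound 4 (0.95 log units; beyond the scatter)), so the cost of the methyl is smaller than the cost of either nitrogen-bearing bicycle. No measured evidence here explains these shifts.

The compounds shown leave open whether a chlorine, a fluorine or an ethyl on that same aromatic carbon would bring the number closer to that of compound 1. They also leave open how the methyl would act on the bicycle of compound 3.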